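The compounds below may be only part of what the source reports. "The series", "measured", "known", "first", "only" and "open" are said of these compounds alone.

The series shares the core of compound 1 `Fc1ccccc1Nc1nc2nonc2nc1NCCC(F)(F)F`. In an assay on mitochondria from L6 cells (Rattus norvegicus) for activation, with a stated time of 90 min (on this read-out lower numbers stand for an effect already at smaller amounts and higher numbers for an effect only at larger amounts of compound), compound 1 gives only a limit, > 100000 nM. Among the compounds with values here, compound 2 `Cc1ccc(Nc2nc3nonc3nc2Nc2ccccc2F)cc1` in this assay gives 2100 nM, the only number so far obtained in it, so compound 2 is the sole fixed point for the series. Within the data shown here, the one measured step, an at least 47-fold lower number from compound 1 to compound 2 (1.67 log units; beyond the scatter), rests on the limit of > 100000 nM in this assay, at which 1 of the 2 values shown sits, at one end, so its size is known only as a lower bound. Compound 3 `COc1ccc(Nc2nc3nonc3nc2Nc2ccccc2F)cc1` differs from compound 2 by methoxy in place of methyl on an aromatic carbon. Among the measured compounds shown here, no measured step touches this position; the step from compound 1 to compound 2 changes a different part of the molecule, the group on the ring nitrogen, and says little about a swap of methyl for methoxy on the phenyl ring. In this assay the expected step is a 1.1-fold lower number from compound 2 to compound 3 (0.02 log units; within the scatter), that is, none beyond the scatter in either direction. The estimate for compound 3 is 2000 nM, between 700 nM and 6000 nM.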

Compound 3, half-maximal effective concentration: 1600 nM
Estimate against measurement, compound 3: 1.3-fold (0.10 log units) above; the measured number falls inside the stated range.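

Methoxy in place of methyl on an aromatic carbon para to a large group gives a 1.3-fold lower number from compound 2 to compound 3 (0.12 log units; within the scatter) in this assay, so this position now has its first measured swap, and the two values cannot be told apart on this read-out. The added oxygen and its hydrogen-bond acceptor therefore bring no difference beyond the scatter in this pair. The large step away from 3,3,3-trifluoropropyl also appears with a second aryl group, 4-methoxyphenyl, as an at least 62-fold lower number from compound 1 to compound 3 (1.79 log units; beyond the scatter), so it is not confined to 4-methylphenyl, although its size is only a lower bound, since it rests on a limit: the limit of > 100000 nM in this assay, at which 1 of the 3 values shown sits.

Methyl and methoxy are the only groups shown at this carbon, so it remains open whether an amine, a carboxylic acid, a chlorine atom or a longer chain such as butoxy would separate from them beyond the scatter. The fluorophenyl group is common to all three compounds, which leaves its contribution to the read-out open as well.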